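A few compounds are considered here, and "the series" means these few. Any claim that something is new, unique, unknown or untested is made for them only; others in the source may bear on it.

In a functional assay on NCI-H1299 cells (Homo sapiens) for antiproliferative activity, read by XTT assay, with a stated time of 72 h (on this read-out lower numbers stand for stronger inhibition and higher numbers for weaker inhibition), compound 2 `COc1ccc(-c2cc3ccccc3nc2/C=C/C(=O)c2ccc(O)cc2)cc1` gives 8970 nM and compound 3 `COc1ccc(C(=O)/C=C/c2nc3ccccc3cc2-c2ccc(OC)cc2)cc1` gives 6420 nM and these two values lie within the scatter of each other. Compound 1 `COc1ccc(-c2cc3ccccc3nc2C=O)cc1` reads > 10000 nM in this assay and this is a limit of the assay, not a number.

Compound 4 `COc1ccc(-c2cc3ccccc3nc2/C=C/C(=O)c2ccc([N+](=O)[O-])cc2)cc1` carries nitro in place of the methoxy of compound 3 on an aromatic carbon, para to a large group, which is the change from 4-methoxyphenyl to 4-nitrophenyl. The count for this change is nitro in place of methoxy on an aromatic carbon and it sets out what leaves and what enters.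

Among the compounds with values here, only one measured step touches this place on the molecule. That step is a 1.4-fold lower number from compound 2 to compound 3 (0.15 log units; within the scatter) and it came from methyl in place of hydrogen on an oxygen. Within the data shown here, no nitro compound has been measured yet, so this step is thin guidance, and no change beyond the scatter is expected. The expected result is a 1.1-fold lower number from compound 3 to compound 4 (0.03 log units; within the scatter) in this assay as a working figure. For compound 4 the estimated value is 6000 nM with an expected range from 2000 nM to 10000 nM for the measurement.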

Compound 4, half-maximal inhibitory concentration: 770 nM
Beside the measured number, compound 4's estimate is 7.8-fold (0.89 log units) above it, outside the stated range (below it).
By their numbers in this assay, from the lowest: compound 4; then compounds 3 and 2 (each within the scatter of the next). At a limit, above all of these: compound 1.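

Before compound 4, the only step at this position stayed within the scatter, so the group on this aromatic carbon could have seemed to matter little. In this assay, nitro in place of methoxy gives an 8.3-fold lower number from compound 3 to compound 4 (0.92 log units; beyond the scatter), and nitro in place of hydroxy gives a 12-fold lower number from compound 2 to compound 4 (1.07 log units; beyond the scatter), which shows that the number does respond to what sits at this position. The measurements shown do not explain why nitro has this effect.

As far as these compounds go, with only hydroxy, methoxy and nitro compared here, it remains open whether nitro is unusual or whether an amine, a nitrile or a carboxylic acid at the same position would give a similar number. It is also unknown whether nitro would give a similar step on another carbon of this ring.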